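The source may report more compounds than this note shows. Statements on the series, on what has been measured and on what is new or still open speak of the compounds shown alone.

Compound 1 `O=[N+]([O-])c1ccc(-c2nc3cc(C(F)(F)F)ccc3[nH]2)c([N+](=O)[O-])c1` gives 25000 nM in an ADME assay on Vero cells (Chlorocebus sabaeus) for cytotoxicity; a higher number here means that more compound is tolerated, a lower number that less compound is tolerated. Compound 2 `O=[N+]([O-])c1ccc(-c2nc3ccccc3[nH]2)c([N+](=O)[O-])c1` in this assay gives only a limit of the assay, > 100000 nM. The step of an at least 4.0-fold higher number from compound 1 to compound 2 (0.60 log units; beyond the scatter) runs up to the limit of > 100000 nM in this assay, at which 1 of the 2 values shown sits, so compound 2 stands at the upper edge of the numbers shown. Compound 3 `O=[N+]([O-])c1ccccc1-c1nc2ccccc2[nH]1` differs from compound 2 by hydrogen in place of nitro on an aromatic carbon. For the measured compounds named here, no measured step touches a nitro group; the only measured step, an at least 4.0-fold higher number from compound 1 to compound 2 (0.60 log units; beyond the scatter), concerns another group. Compound 3 is therefore expected to stay near the limit, with a number no higher from compound 2 to compound 3 (the limit leaves the size open) expected to be small. In this assay compound 3 is estimated at 100000 nM, within 30000 nM to 300000 nM.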

Compound 3, half-maximal cytotoxic concentration: > 100000 nM
Compound 3 gave a limit, no number; the forecaster's own chance of this, stated with the estimate: 60%; the middle value sits exactly at the limit.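

In this assay compound 3 gives only a limit of the assay, > 100000 nM, as compound 2 does, so no step can be read between compound 2 and compound 3. The compounds shown leave open what hydrogen in place of nitro does to the number.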